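A few compounds are considered here, and "the series" means these few. Any claim that something is new, unique, unknown or untested is made for them only; others in the source may bear on it.

Compound 1 `CC(Oc1ccccc1-c1ccncc1)C1=NCCN1`: in a functional assay on CHO cells for agonist activity at Alpha-2C adrenergic receptor (Homo sapiens) (a lower number here means a smaller maximal response, a higher number a larger maximal response), compound 1 gives < 0.3, a limit of the assay and not a number.
Compound 2 `CC(Oc1ccccc1-c1ccccn1)C1=NCCN1`: in this assay compound 2 gives < 0.3, again a limit of the assay rather than a number.

Compound 2 thus stands only at a limit in this assay; how far its true maximal response lies under that mark cannot be read. Among the measured compounds shown here, the single measured step, a step that the two limits leave unreadable from compound 1 to compound 2, likewise has no readable size, and the only evidence available is the limit of < 0.3 in this assay, at which 2 of the 2 values shown sit. The unmeasured compound 3 `CC(Oc1ccccc1-c1cccs1)C1=NCCN1` differs from compound 2 in one place: thiophen-2-yl in place of pyridin-2-yl on an aromatic carbon. For the measured compounds named here, no measured step speaks to this change beyond the fact that both measured compounds sit at the same limit; neither direction nor size can be drawn from them. What is expected for compound 3 in this assay is a maximal response that again stays small, most probably again reported only as a limit. Compound 3 is estimated at 0.2, within 0.05 to 0.4. The step that the limit leaves unreadable from compound 2 to compound 3 that this estimate implies is expected to lie within the scatter.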

Compound 3, intrinsic activity: the largest response reached, as a fraction of the reference agonist's: 0.8
Beside the measured number, compound 3's estimate is 0.60 below it; the whole stated range lies below it.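

The aromatic carbon ortho to a group of 8 heavy atoms now proves able to carry a large maximal response in this assay, which the two pyridine-bearing compounds could not show, as both stayed at a limit. Replacing pyridin-2-yl with thiophen-2-yl gives a number at least 0.50 higher from compound 2 to compound 3 (beyond the scatter), and replacing pyridin-4-yl with thiophen-2-yl gives a number at least 0.50 higher from compound 1 to compound 3 (beyond the scatter), so the outcome at this position depends strongly on which aromatic ring sits there. Both steps can be given only as minimum sizes, because the true responses of compound 1 and compound 2 remain unread: the limit of < 0.3 in this assay, at which 2 of the 3 values shown sit.

From the compounds shown here alone, the change swaps a six-membered aromatic ring holding nitrogen for a five-membered aromatic ring holding sulfur, and it remains open whether ring size or the hetero atom accounts for the rise, a question that a phenyl or a furan-2-yl group at this position would help to settle. Also open, going by these compounds, is how the response in this assay would shift with a chlorine atom or an amine on the thiophen-2-yl ring.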